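Chloro for fluoro on the benzoyl ring of compound 2

The source may hold more compounds than are shown below. What is called first, only, known or untested is meant among the compounds shown, and "the series" means these compounds.

Measured so far:
compound 1, `NCC(=O)NCc1nncn1-c1ccc(Cl)cc1C(=O)c1ccccc1`: 31.7 mg/kg
compound 2, `Cc1nnc(CNC(=O)CN)n1-c1ccc(Cl)cc1C(=O)c1ccccc1F`: 1.52 mg/kg
compound 3, `CN(C(=O)CNC(=O)CN)c1ccc(Cl)cc1C(=O)c1ccccc1Cl`: 1.4 mg/kg

In a functional assay on the whole organism for inhibition, with Mus musculus as the target (a higher number here means that more compound is needed for the effect, a lower number that less compound is needed), compound 2 gives 1.52 mg/kg, the second highest of the three numbers. Compound 3 gives 1.4 mg/kg, within the scatter of compound 2, whereas compound 1 gives 31.7 mg/kg, a gap beyond the scatter. For the measured compounds named here, no pair of measured compounds differs in only one place, so no single-change step is known in this assay. Compound 4, `Cc1nnc(CNC(=O)CN)n1-c1ccc(Cl)cc1C(=O)c1ccccc1Cl`, is not yet measured. It differs from compound 2 as follows: chloro in place of fluoro on an aromatic carbon. Compound 3 already carries a 2-chlorophenyl group on another core and gives a number within the scatter of compound 2, so the expected step of a 1.2-fold lower number from compound 2 to compound 4 (0.07 log units; within the scatter) is small, none beyond the scatter. Compound 4 is estimated at 1.3 mg/kg, range 0.5 mg/kg to 3.5 mg/kg.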

Compound 4, dose for half-maximal effect: 0.31 mg/kg
Beside the measured number, compound 4's estimate is 4.2-fold (0.62 log units) above it; the measured number lies below the stated range.
By their numbers in this assay, from the lowest: compound 4; then compounds 3 and 2 (each within the scatter of the next); then compound 1.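

this assay shows a 4.9-fold lower number from compound 2 to compound 4 (0.69 log units; beyond the scatter) with 2-chlorophenyl in place of 2-fluorophenyl, a step beyond the scatter. For the compounds shown here, this is the first single-change comparison, and it shows that the choice of halogen on an aromatic carbon ortho to a large group alters the dose needed on this core. No available evidence accounts for the step.

Going by these compounds, whether bromo, methyl or trifluoromethyl at this place extends the step remains open. On these data alone, the effect of hydrogen there on the core of compound 4 also remains open.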